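Cytotoxicity notes: aryl-substituted quinoline amine series, compound 4

This account rests on a few compounds, and the source may have more. Where it says the series, first, only, none or still open, it means among the compounds named here.

Compound 3 `CN(C)c1cccc(Oc2ccc3c(NCCCNCc4ccco4)ccnc3c2)c1` gives 16000 nM in an ADME assay on HepG2 cells (Homo sapiens) for cytotoxicity, read by luminescence, CellTiter-Glo and ATP content, with a stated time of 72 h (on this read-out higher numbers stand for an effect only at larger amounts of compound and lower numbers for an effect already at smaller amounts), the highest of the three numbers measured; compound 1 `COc1ccc(-c2ccc3c(NCCCNCc4ccco4)ccnc3c2)cc1` gives 6000 nM and compound 2 `CC(C)(C)c1ccc(-c2ccc3c(NCCCNCc4ccco4)ccnc3c2)cc1` gives 3150 nM. Compound 4 `N#Cc1ccc(Cc2ccc3c(NCCCNCc4ccco4)ccnc3c2)cc1` is not yet measured. It differs from compound 3 by 4-cyanobenzyl in place of 3-(dimethylamino)phenoxy on an aromatic carbon. Within the data shown here, the steps that bear on this change are those leading into compound 3: a 2.7-fold higher number from compound 1 to compound 3 (0.43 log units; beyond the scatter) and a 5.1-fold higher number from compound 2 to compound 3 (0.71 log units; beyond the scatter), both modest and beyond the scatter, while a 1.9-fold lower number from compound 1 to compound 2 (0.28 log units; within the scatter) stays within it. Undoing the phenoxy substituent in favour of a benzyl group with a nitrile is therefore expected to move the number back towards those of compound 1 and compound 2, a step of about a 2.7-fold lower number from compound 3 to compound 4 (0.43 log units; beyond the scatter). Compound 4 is estimated at 6000 nM, with a range from 2500 nM to 15000 nM.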

Compound 4, half-maximal effective concentration in the HepG2 assay: 7910 nM
Compound 4: the middle estimate sits 1.3-fold (0.12 log units) below what was measured; low and high end bracket the measured number.
By their numbers in the HepG2 assay, from the lowest: compounds 2, 1 and 4 (each within the scatter of the next, the first and the last beyond it); then compound 3.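

In the HepG2 assay 4-cyanobenzyl at this position gives a 2.0-fold lower number from compound 3 to compound 4 (0.31 log units; beyond the scatter) and a 2.5-fold higher number from compound 2 to compound 4 (0.40 log units; beyond the scatter) but only a 1.3-fold higher number from compound 1 to compound 4 (0.12 log units; within the scatter) so compound 3 stays apart from the other three on this read-out. The same change also separates the compounds in a physicochemical assay for solubility, with a stated time of 18 h, at pH 7.4 (a higher number here means a more soluble compound, a lower number a less soluble compound), where compound 3 gives 14500 nM and compound 4 gives 4200 nM which is a 3.5-fold lower number from compound 3 to compound 4 (0.54 log units; beyond the scatter) on this read-out.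

On these data alone, it stays open whether the higher number of compound 3 goes with the oxygen link, the dimethylamino group or both. A 3-(dimethylamino)benzyl or 4-cyanophenoxy group at this position would separate the link from the ring substituent.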